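The source may report more compounds than this note shows. Statements on the series, on what has been measured and on what is new or still open speak of the compounds shown alone.

Measured in a functional assay on HeLa S3 cells (Homo sapiens) for cytotoxicity, read by XTT assay, with a stated time of 3 days; a lower number here means a stronger inhibitor, a higher number a weaker inhibitor:
- Compound 1 `OC[C@H]1O[C@@H](n2cc(F)c3c(-c4ccsc4)ncnc32)[C@H](O)[C@@H]1O`: 210 nM
- Compound 2 `OC[C@H]1O[C@@H](n2cc(F)c3c(-c4cc[nH]c4)ncnc32)[C@H](O)[C@@H]1O`: 8900 nM

Compound 1 holds the lower of the two numbers in this assay. Within the data shown here, the only measured step is a 42-fold higher number from compound 1 to compound 2 (1.63 log units; beyond the scatter), which is large and beyond the scatter. That step places 1H-pyrrol-3-yl in place of thiophen-3-yl on an aromatic carbon, so it shows how far the numbers can move in this small series, but only for a change at that group.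

The next compound to be measured is compound 3 `OC[C@H]1O[C@@H](n2cc(Cl)c3c(-c4ccsc4)ncnc32)[C@H](O)[C@@H]1O`, which keeps the thiophen-3-yl group. Its difference from compound 1 is chloro in place of fluoro on an aromatic carbon. This is chloro in place of fluoro on an aromatic carbon. Among the measured compounds shown here, no measured step covers a change at this place, so the size of the pyrrole step does not carry over. No step beyond the scatter is expected in this assay, and no direction is favoured. For the measured compounds named here, the range is kept wide because the data hold no direct precedent.

The estimate for compound 3 is an expected 200 nM, with an expected range of 60 nM to 700 nM. The expected change is a 1.1-fold lower number from compound 1 to compound 3 (0.02 log units; within the scatter).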

Compound 3, half-maximal inhibitory concentration: 340 nM
Beside the measured number, compound 3's estimate is 1.7-fold (0.23 log units) below it; low and high end bracket the measured number.
By their numbers in this assay, from the lowest: compounds 1 and 3 (each within the scatter of the next); then compound 2.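

In this assay, among these compounds, chloro in place of fluoro gives a 1.6-fold higher number from compound 1 to compound 3 (0.21 log units; within the scatter), the first measured change at this aromatic carbon of the five-membered aromatic ring with 1 nitrogen, and with the thiophen-3-yl group held fixed the two compounds cannot be told apart. Set against a 42-fold higher number from compound 1 to compound 2 (1.63 log units; beyond the scatter), the numbers in this small series move far with the change at the thiophen-3-yl group but show no readable move with this one swap of fluoro and chloro, a statement that rests on a single pair of compounds. No supporting measurement is available that would bear on this result or explain it.

It remains open whether this carbon tolerates other groups, such as a methyl, a nitrile or an amine, or whether the flat result is limited to the two halogens shown. From the compounds shown here alone, it also remains open whether chloro in place of fluoro would leave the number as little changed alongside the 1H-pyrrol-3-yl group of compound 2, since the present step was read only with the thiophen-3-yl group in place.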